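A few compounds are considered here, and "the series" means these few. Any claim that something is new, unique, unknown or untested is made for them only; others in the source may bear on it.

Working notes on the series. Within the data shown here, compound 1 `CC(C)(C)OC(=O)NCCCC(=O)O[C@H]1[C@H](O)[C@@H](CO)O[C@H]1n1cc(/C=C/Br)c(=O)[nH]c1=O` is the only member with a number in an assay on isolated protein for inhibition of Deoxynucleoside kinase (Drosophila melanogaster); on this read-out higher numbers stand for weaker inhibition and lower numbers for stronger inhibition; compound 1 gives 133000 nM. Compound 2 `CCCCCCCC(=O)O[C@H]1[C@H](O)[C@@H](CO)O[C@H]1n1cc(C)c(=O)[nH]c1=O` belongs to the same set of esters on the shared core. For compound 2 the result in this assay is a limit rather than a number, > 1000000 nM. That places one of the two values shown at the limit of > 1000000 nM in this assay, at which 1 of the 2 values shown sits, so compound 1 stands alone as the sole measured point against which the next step can be set.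

Compound 3 `NCCCCCC(=O)O[C@H]1[C@H](O)[C@@H](CO)O[C@H]1n1cc(/C=C/Br)c(=O)[nH]c1=O` is the unmeasured partner of compound 1. The change from compound 1 to compound 3 is 2-aminoethyl in place of (tert-butoxycarbonyl)amino on a saturated chain carbon, three bonds along the chain from a carbonyl carbon, in words: 2-aminoethyl in place of (tert-butoxycarbonyl)amino on a saturated chain carbon, three bonds along the chain from a carbonyl carbon. Among the measured compounds shown here, no step between two measured compounds is available for this kind of change, so the expected size rests on compound 1 alone. The expected step from compound 1 to compound 3 is a 1.7-fold lower number from compound 1 to compound 3 (0.22 log units; within the scatter), a modest move toward stronger inhibition that may not exceed the usual scatter. Compound 3 is accordingly estimated at 80000 nM, with a range from 20000 nM to 320000 nM.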

Compound 3, half-maximal inhibitory concentration: > 500000 nM
Compound 3 gave a limit, no number; the forecaster's own chance of this, stated with the estimate: 15%; middle value at least 6.2-fold (0.79 log units) away from the limit.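

In this assay this change gives an at least 3.7-fold higher number from compound 1 to compound 3 (0.57 log units; beyond the scatter), so what the ester chain carries at this place does matter to the read-out, and the direction is toward weaker inhibition. Compound 3 gives a limit of the assay, not a number: the limit of > 500000 nM in this assay, at which 1 of the 3 values shown sits. The step therefore fixes only a minimum size and a direction, and compound 1 remains the only ester in the set with a number, which leaves no measured point on the stronger side of it.

The compounds shown do not separate the two things that change together here, the loss of the (tert-butoxycarbonyl)amino group and the lengthening from 3-((tert-butoxycarbonyl)amino)propyl to 5-aminopentyl, so neither can yet be credited with the step. As far as these compounds go, a 3-aminopropyl group on the ester carbonyl, a 5-((tert-butoxycarbonyl)amino)pentyl group in the same place, or a carboxylic acid at the chain end would each bear on that question, and it also remains open how far above the limit compound 3 actually lies.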